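The source may hold more compounds than are shown below. What is called first, only, known or untested is meant among the compounds shown, and "the series" means these compounds.

Compound 1 `COc1cc2c(cc1OC)C(c1cccc(N)c1)=NN=C(S)C2` gives 9.1 umol/kg in a functional assay on the whole organism with Mus musculus as the target; a higher number here means that more compound is needed for the effect, a lower number that less compound is needed
Compound 2 `COc1cc2c(cc1OC)C(c1ccc(Br)cc1)=NNC(=O)C2` gives 82.5 umol/kg in this assay
Compound 3 `COc1cc2c(cc1OC)C(c1ccccc1)=NN(C)C(=S)C2` gives 24.7 umol/kg in this assay

Of these three, compound 2 has the highest number, so it needs the most compound for the effect. Compound 3 lies nearest to it and compound 1 furthest, both lower by more than the usual scatter. Compound 4 `COc1cc2c(cc1OC)C(c1ccc(Cl)cc1)=NNC(=O)C2` has not yet been measured. It departs from compound 2 by one change: chloro in place of bromo on an aromatic carbon. For the measured compounds named here, no two measured compounds differ in one place alone, so the data give no direct measure of such a change. No step beyond the scatter is expected in this assay, and no direction is favoured. The expectation therefore rests on compound 2 at 82.5 umol/kg alone. The expected step is a 1.2-fold lower number from compound 2 to compound 4 (0.07 log units; within the scatter), an estimate within the usual scatter. Compound 4 is estimated at 70 umol/kg, with an expected range from 30 umol/kg to 160 umol/kg in this measurement.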

Compound 4, dose for half-maximal effect: 75.3 umol/kg
Beside the measured number, compound 4's estimate is 1.1-fold (0.03 log units) below it; low and high end bracket the measured number.
By their numbers in this assay, from the lowest: compound 1; then compound 3; then compounds 4 and 2 (each within the scatter of the next).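

In this assay, for the compounds shown here, the exchange of 4-bromophenyl for 4-chlorophenyl is the first change read on its own (a 1.1-fold lower number from compound 2 to compound 4 (0.04 log units; within the scatter)). Compound 2 and compound 4 stand within the scatter of each other, so at this place, para to a large group, chloro and bromo cannot be told apart in this whole-organism measure. No measurement shown offers an explanation for this result. On these data alone, whether fluoro, methoxy or trifluoromethyl at the same place would also stay within the scatter remains open. So does the effect of an unsubstituted phenyl on the core of compound 2.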